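The source may hold more compounds than are shown below. What is called first, only, known or untested is meant among the compounds shown, and "the series" means these compounds.

Compound 2, `CC(C)[C@H](NC(=O)COc1cccc2ccccc12)C(=O)N[C@@H](CC(=O)O)C(=O)COc1cc(F)c(F)cc1F`, and compound 1, `CC(C)[C@H](NC(=O)COc1cccc2ccccc12)C(=O)N[C@@H](CC(=O)O)C(=O)COc1ccc([N+](=O)[O-])cc1`, share the same core and differ only in the aryl group on an oxygen on a saturated carbon. For the measured compounds named here, in a functional assay on Jurkat cells (Homo sapiens) (a higher number here means a weaker inhibitor, a lower number a stronger inhibitor), compound 2 gives 39300 nM, the only plain number measured so far. Compound 1 gives > 100000 nM, which is a limit of the assay rather than a number. Going by the values given here, the step of an at least 2.5-fold lower number from compound 1 to compound 2 (0.40 log units; beyond the scatter) is the one measured step available, and it rests on (the limit of > 100000 nM in this assay, at which 1 of the 2 values shown sits). Compound 3, `CC(C)[C@H](NC(=O)COc1cccc2ccccc12)C(=O)N[C@@H](CC(=O)O)C(=O)COc1cccc(C(F)(F)F)c1F`, carries the change (2-fluoro-3-(trifluoromethyl)phenyl in place of 2,4,5-trifluorophenyl on an oxygen on a saturated carbon). Among the compounds with values here, no measured step tests this change directly; the one step available shows only that exchanging the aryl group on this oxygen can move the number, while compound 2 and compound 3 both carry fluorinated phenyl groups at this place. The expected step is therefore a 1.3-fold lower number from compound 2 to compound 3 (0.12 log units; within the scatter), within the scatter. Compound 3 is estimated at 30000 nM, with a range from 8000 nM to 100000 nM.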

Compound 3, half-maximal inhibitory concentration: 50400 nM
Compound 3: the middle estimate sits 1.7-fold (0.23 log units) below what was measured; low and high end bracket the measured number.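

In this assay, changing one fluorinated aryl group for another on this oxygen makes no measurable difference: the step is a 1.3-fold higher number from compound 2 to compound 3 (0.11 log units; within the scatter). For the compounds shown here, the larger 2-fluoro-3-(trifluoromethyl)phenyl group is therefore tolerated as well as 2,4,5-trifluorophenyl, which the single earlier step could not show. The comparison with the 4-nitrophenyl group is less informative, since the step is an at least 1.9-fold lower number from compound 1 to compound 3 (0.29 log units; that floor lies within the scatter), so compound 3 cannot be firmly separated from compound 1, and this reading rests on a limit of the assay: the limit of > 100000 nM in this assay, at which 1 of the 3 values shown sits.

Compound 2 and compound 3 differ in both the number and the placement of their fluorine-bearing groups, so the contribution of each remains unresolved. On these data alone, it also remains open how the number would respond to an unsubstituted phenyl ring, a phenyl ring carrying a nitrile or an amine, or a saturated carbon chain on this oxygen.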